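Three Limits and an Expected Fourth

The compounds below may be only part of what the source reports. "The series", "measured", "known", "first", "only" and "open" are said of these compounds alone.

Compound 1 `O=C(Nc1cccc(-n2cc(-c3ccncc3)c(-c3ccc(Cl)c(O)c3)n2)c1)Nc1ccc(Cl)c(Cl)c1`, compound 2 `COc1cc(-c2nn(-c3cccc(NC(=O)c4ccc(Cl)c(C(F)(F)F)c4)c3)cc2-c2ccncc2)ccc1Cl` and compound 3 `COc1cc(-c2nn(-c3cccc(NC(=O)c4cccc(C(F)(F)F)c4)c3)cc2-c2ccncc2)ccc1Cl` share one core and were each tested in a functional assay on SN12C cells (Homo sapiens) for inhibition, read by sulforhodamine B assay, with a stated time of 48 h; on this read-out lower numbers stand for higher toxicity in this test and higher numbers for lower toxicity in this test. For compound 1 the result in this assay is only a limit, > 32500 nM. Compound 2 likewise gives only a limit in this assay, > 32500 nM. Compound 3 also stays at a limit in this assay, > 50000 nM. Going by the values given here, all three rest at the test ceilings (the limit of > 32500 nM in this assay, at which 2 of the 3 values shown sit, (the limit of > 50000 nM in this assay, at which 1 of the 3 values shown sits)), and the single measured change, a step that the two limits leave unreadable from compound 2 to compound 3, cannot be sized. Compound 4 `COc1cc(-c2nn(-c3cccc(NC(=O)Nc4ccc(Cl)c(C(F)(F)F)c4)c3)cc2-c2ccncc2)ccc1Cl` differs from compound 3 by (4-chloro-3-(trifluoromethyl)phenyl)amino in place of 3-(trifluoromethyl)phenyl on a carbonyl carbon. No readable step bears on this change. With every neighbour at a limit, no shift beyond the scatter is expected, and the step of an at least 1.2-fold lower number from compound 3 to compound 4 (0.09 log units; that floor lies within the scatter) is an estimate only. Compound 4 is therefore expected at 40000 nM, within 12000 nM to 120000 nM.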

Compound 4, concentration lethal to 50% of the cells: > 32500 nM
Compound 4 was reported as a limit; the forecaster's own chance of this, stated with the estimate: 80%; the middle value lies beyond the limit too.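

In this assay compound 4 gives > 32500 nM, which is only a limit. Going by these compounds alone, no step among compound 2, compound 3 and compound 4 can be read. The compounds shown leave open whether any of these changes alters toxicity in this test.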